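From Hydroxypyrrolidinyl Amide to Carboxylic Acid

The source may hold more compounds than are shown below. What is called first, only, known or untested is meant among the compounds shown, and "the series" means these compounds.

In an ADME assay on microsomes from liver (Homo sapiens) for metabolic stability, read by LC-MS, using NADPH, with a stated time of 30 min, tested at 0.1 uM, in the presence of a further agent that is not named here (a higher number here means that more of the compound is left, a lower number that less of the compound is left), compound 1 (`NC(=O)c1ccc(-c2cnc(N)c(-c3ccc(C(F)(F)F)cc3)n2)cc1`) gives > 90% as a limit of the assay. Compound 2 (`Nc1ncc(-c2ccc(C(=O)N3CC[C@@H](O)C3)cc2)nc1-c1ccc(C(F)(F)F)cc1`) gives > 90% which is likewise a limit. Compound 3 (`Nc1ncc(-c2ccc(C(=O)O)cc2)nc1-c1ccc(C(F)(F)F)cc1`) carries hydroxy in place of 3-hydroxypyrrolidin-1-yl on a carbonyl carbon. Within the data shown here, the one measured step at this carbonyl carbon is a step that the two limits leave unreadable from compound 1 to compound 2 and its size cannot be read. Among the measured compounds shown here, the only evidence is the limit of > 90% in this assay, at which 2 of the 2 values shown sit, and it offers no sign of a loss. The estimated change is a step that the limit leaves unreadable from compound 2 to compound 3 and no shift beyond the scatter is expected in this assay for this change. For compound 3 the expected value is 95% with an estimated range from 82% to 100% in this reading.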

Compound 3, percent of the compound remaining: > 90%
Compound 3: a limit, no number (the forecaster's own chance of this, stated with the estimate: 65%); the middle value does not contradict the limit.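

In this assay, among these compounds, compound 1, compound 2 and compound 3 all give limits, not numbers, and no step among them can be read. The compounds shown leave open whether any replacement on this carbonyl carbon changes the percent remaining.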